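A few compounds are considered here, and "the series" means these few. Any claim that something is new, unique, unknown or untested is made for them only; others in the source may bear on it.

Measured so far:
compound 1 `COc1cc(N(Cc2ccc(F)cc2)C(=O)CSc2nc3ccccc3s2)cc(OC)c1OC`, 59800 nM
compound 2 `COc1ccc(CN(C(=O)CSc2nc3cc(Br)ccc3s2)c2cc(OC)c(OC)c(OC)c2)cc1O`, 3380 nM
compound 3 `COc1ccc(CN(C(=O)CSc2nc3cc(Cl)ccc3s2)c2cc(OC)c(OC)c(OC)c2)cc1O`, 429 nM

In a functional assay on HCT-116 cells (Homo sapiens) for antiproliferative activity, read by MTT assay, with a stated time of 48 h (a higher number here means a weaker inhibitor, a lower number a stronger inhibitor), compound 1 stands highest of the three numbers, so it is the weakest inhibitor shown; compound 2 sits well below it and compound 3 lowest. Among the compounds with values here, the only single-point step measured, a 7.9-fold lower number from compound 2 to compound 3 (0.90 log units; beyond the scatter), concerns the halogen on the shared core and does not touch the change studied here.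

Compound 4 is `COc1ccc(CN(C(=O)CSc2nc3ccccc3s2)c2cc(OC)c(OC)c(OC)c2)cc1N=[N+]=[N-]`. It differs from compound 1 by 3-azido-4-methoxyphenyl in place of 4-fluorophenyl on a saturated chain carbon bound to an amide-type nitrogen. Within the data shown here, no measured step bears directly on this change, so only the values of compounds 2 and 3, which carry a substituted benzyl group and lie far below compound 1, give a hint.

Compound 4 is therefore expected to give a lower number than compound 1, an estimated step of a 10-fold lower number from compound 1 to compound 4 (1.00 log units; beyond the scatter), with an estimated value of 6000 nM (range 900 nM to 35000 nM).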

Compound 4, half-maximal inhibitory concentration: 2860 nM
Compound 4: middle estimate off by 2.1-fold (0.32 log units), on the high side; the range from low to high includes it.
By their numbers in this assay, from the lowest: compound 3; then compounds 4 and 2 (each within the scatter of the next); then compound 1.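

In this assay, 3-azido-4-methoxyphenyl in place of 4-fluorophenyl on a saturated chain carbon bound to an amide-type nitrogen gives a 21-fold lower number from compound 1 to compound 4 (1.32 log units; beyond the scatter) with nothing else changed. This shows that the group at this position can strongly shift the antiproliferative reading, independently of any halogen on the shared core. No measurement shown here explains the size of this step.

On these data alone, because the azido and methoxy groups enter together as the fluorine leaves, the contribution of each remains open. As far as these compounds go, it is also open how an amine in place of the azido group would read.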